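Swapping cyclohexylamino for methylsulfanyl at the assay's limit

The source may hold more compounds than are shown below. What is called first, only, known or untested is meant among the compounds shown, and "the series" means these compounds.

In an ADME assay on BCBL1 cells (Homo sapiens) for cytotoxicity, with a stated time of 7 days (a higher number here means that more compound is tolerated, a lower number that less compound is tolerated), compound 1 `COCCOc1nc(N)nc2c1ncn2/C=C1/CC1(CO)CO` gives > 20000 nM, which is a limit of the assay and not a number. Compound 2 `Nc1nc(NC2CCCCC2)c2ncn(/C=C3/CC3(CO)CO)c2n1` gives > 20000 nM, also only a limit. Compound 2 therefore has no exact value, and the only other result is a limit too: the limit of > 20000 nM in this assay, at which 2 of the 2 values shown sit.

Compound 3 `CSc1nc(N)nc2c1ncn2/C=C1/CC1(CO)CO` carries methylsulfanyl in place of cyclohexylamino on an aromatic carbon. Among the measured compounds shown here, the one measured step at this carbon is a step that the two limits leave unreadable from compound 1 to compound 2. It exchanged two different groups, yet it gives no size to carry over. With so little to go on, no step beyond the usual scatter is expected in this assay, and no direction can be predicted.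

The estimated value for compound 3 is 20000 nM, with an expected range from 8000 nM to 40000 nM. This estimate means an expected a number no higher from compound 2 to compound 3 (the limit leaves the size open).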

Compound 3, half-maximal cytotoxic concentration: > 20000 nM
Compound 3: no number, only a limit (the forecaster's own chance of this, stated with the estimate: 75%); the middle value lies on the limit itself.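

The steps among compound 1, compound 2 and compound 3 cannot be read, since each result is only a limit and not a number: the limit of > 20000 nM in this assay, at which 3 of the 3 values shown sit.

On these data alone, what remains open is whether 2-methoxyethoxy, cyclohexylamino or methylsulfanyl on that aromatic carbon changes how much compound the cells tolerate.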